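The source may hold more compounds than are shown below. What is called first, only, known or untested is meant among the compounds shown, and "the series" means these compounds.

Measured so far:
compound 1, `CC(C)C(c1nnc[nH]1)c1ccc(-c2ccc3cccc(F)c3c2)[nH]c1=O`: 0.905 h
compound 2, `CCn1ncc2c(F)cc(-c3ccc(C(CC)(CC)c4nnc(C)[nH]4)c(=O)[nH]3)cc21`: > 3 h
compound 3, `CCn1ncc2c(F)cc(-c3ccc(C(CC)(CC)c4ncn(C)n4)c(=O)[nH]3)cc21`: > 3 h

Among the compounds with values here, in an ADME assay on microsomes from liver (Homo sapiens) for metabolic stability (a higher number here means that the compound lasts longer, a lower number that the compound disappears faster), compound 1 gives 0.905 h, the only plain number. Compound 2 sits at the limit of the assay with > 3 h. Compound 3 also sits at that limit with > 3 h. Within the data shown here, the one step between measured compounds, a step that the two limits leave unreadable from compound 2 to compound 3, exchanges one methyl-triazolyl arrangement for another, and both values rest at the limit of > 3 h in this assay, at which 2 of the 3 values shown sit, so its size cannot be read.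

Compound 4, `CC(C)C(c1ccc(-c2ccc3cccc(F)c3c2)[nH]c1=O)N1CCNC1=O`, has yet to be measured in this assay. It differs from compound 1 at a single place: 2-oxoimidazolidin-1-yl in place of 4H-1,2,4-triazol-3-yl on a saturated chain carbon bound to an aromatic carbon and a saturated chain carbon. No measured step exchanges a triazolyl ring for a 2-oxoimidazolidin-1-yl ring, and the only step shown is unreadable, so nothing here points to a change in either direction. Compound 1 is therefore taken as the anchor, and a step within the usual scatter is expected. Compound 4 is estimated at 1 h, with a range from 0.45 h to 2.2 h. The expected step of a 1.1-fold higher number from compound 1 to compound 4 (0.04 log units; within the scatter) is within the scatter.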

Compound 4, half-life: 1.03 h
For compound 4 the middle estimate is 1.0-fold (0.01 log units) below the measured one, and the stated range covers the measured number.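

Within the data shown here, this is the first readable step at this place, since the only earlier step cannot be read: in this assay, the exchange on the saturated chain carbon gives a 1.1-fold higher number from compound 1 to compound 4 (0.06 log units; within the scatter). On the core of compound 1, a five-membered non-aromatic ring with 2 hetero atoms therefore cannot be told apart from a five-membered aromatic ring with 3 hetero atoms, so aromaticity of the ring at this place is not required for a half-life of this size. No measured property shown here bears on this result.

As far as these compounds go, whether a primary amine or a carboxylic acid at this place would read the same remains open. Also open, from the compounds shown here alone, is how 2-oxoimidazolidin-1-yl would read on the core of compound 2, whose > 3 h is a limit of the assay.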